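A few compounds are considered here, and "the series" means these few. Any claim that something is new, unique, unknown or untested is made for them only; others in the source may bear on it.

Going by the values given here, compound 2, `C#CCNC1CCc2c(SCCc3cccc(Br)c3)cccc21`, gives in an assay on isolated protein for inhibition of Amine oxidase [flavin-containing] B (Homo sapiens) (a higher number here means a weaker inhibitor, a lower number a stronger inhibitor), a value of 30500 nM, the highest of the three numbers measured so far. Compound 3, `C#CCNC1CCc2c(SCc3cccc(Cl)c3)cccc21`, gives 23300 nM, which sits within the scatter of compound 2. Compound 1, `C#CCNC1CCc2c(SCCc3cccc(C(F)(F)F)c3)cccc21`, gives 3720 nM, and the step of an 8.2-fold higher number from compound 1 to compound 2 (0.91 log units; beyond the scatter) shows that replacing a trifluoromethyl with a bromo on an aromatic carbon weakens the inhibitor noticeably.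

The next compound, compound 4, `C#CCNC1CCc2c(SCCc3ccc(OC)cc3)cccc21`, takes compound 2 and changes the aryl group at the end of the sulfur-linked chain: 4-methoxyphenyl in place of 3-bromophenyl on a saturated chain carbon, two bonds along the chain from a sulfur. Among the compounds with values here, no measured step describes a bromo giving way to a methoxy, nor a move from a 3-substituted to a 4-substituted phenyl; the step of an 8.2-fold higher number from compound 1 to compound 2 (0.91 log units; beyond the scatter) only shows that the group on this ring can shift this assay noticeably. The expectation is therefore wide, with compound 4 estimated at 15000 nM, between 4000 nM and 60000 nM, a step of a 2.0-fold lower number from compound 2 to compound 4 (0.31 log units; beyond the scatter) expected from compound 2 to compound 4.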

Compound 4, half-maximal inhibitory concentration: 62000 nM
The estimate for compound 4 lay 4.1-fold (0.62 log units) below the measured number; measured number above the stated range.
By their numbers in this assay, from the lowest: compound 1; then compounds 3 and 2 (each within the scatter of the next); then compound 4.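

In this assay, the step of a 2.0-fold higher number from compound 2 to compound 4 (0.31 log units; beyond the scatter) shows that 4-methoxyphenyl in place of 3-bromophenyl, on a saturated chain carbon, two bonds along the chain from a sulfur, gives a weaker inhibitor. This change swaps the group on the ring and moves its place on the ring at once, so the step cannot say which of the two matters. Nothing measured here explains the rise in the number.

The compounds shown leave open how 3-methoxyphenyl or 4-bromophenyl would compare, either of which would separate the swap of group from the move on the ring. They also leave open how a plain phenyl or a longer chain would read in this assay at this position.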